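A few compounds are considered here, and "the series" means these few. Any claim that something is new, unique, unknown or untested is made for them only; others in the source may bear on it.

In a functional assay (Nicotiana tabacum) (a higher number here means a weaker inhibitor, a lower number a stronger inhibitor), compound 1 `CSc1nc(NC2CCC2)c2cccnc2n1` gives 720 nM and compound 2 `CSc1nc(NC2CCCC2)c2cccnc2n1` gives 490 nM, two values within the scatter of each other. Compound 3 `CCCCC(CC)CNc1nc(SC)nc2ncccc12` gives 15900 nM, a far higher number than that of compound 2. Compound 2 therefore stands at the low end of this small set, level with compound 1.

Compound 4 `CSc1nc(Nc2ccccc2)c2cccnc2n1` carries phenyl in place of cyclopentyl on a nitrogen on an aromatic ring. Among the compounds with values here, the only measured step that bears directly on this change is a 1.5-fold lower number from compound 1 to compound 2 (0.17 log units; within the scatter). That step exchanges cyclobutyl for cyclopentyl and involves no phenyl, so it offers only a loose guide. Compound 3, at 15900 nM, shows that another group on that nitrogen can come with a much higher number.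

A moderate rise in this assay is expected, though with wide uncertainty, and the estimated change is a 2.0-fold higher number from compound 2 to compound 4 (0.31 log units; beyond the scatter). For compound 4 the estimate is 1000 nM, with an expected range from 250 nM to 6000 nM.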

Compound 4, half-maximal inhibitory concentration: 15900 nM
Estimate against measurement, compound 4: 16-fold (1.20 log units) below, and the stated range ends below it.
By their numbers in this assay, from the lowest: compounds 2 and 1 (each within the scatter of the next); then compounds 3 and 4 (each within the scatter of the next).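

In this assay, the step to an aromatic ring on this nitrogen is large: a 32-fold higher number from compound 2 to compound 4 (1.51 log units; beyond the scatter), and a 22-fold higher number from compound 1 to compound 4 (1.34 log units; beyond the scatter), whereas the earlier change between the two non-aromatic rings stayed within the scatter. Compound 4 at 15900 nM thus stands level with compound 3 at 15900 nM, so phenyl and the open chain of compound 3 both give numbers far higher than those of cyclobutyl and cyclopentyl. Nothing measured here explains this rise.

The compounds shown leave open whether the rise follows from the aromatic character of the entering ring or from its being six-membered, a question that cyclohexyl on the same nitrogen would address. They also leave open whether benzyl, which sets phenyl one carbon away from that nitrogen, would give a number nearer that of compound 2 or compound 4.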